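Sulfonate esters on MCF7 cells: a small aryl series

The compounds below may be only part of what the source reports. "The series", "measured", "known", "first", "only" and "open" are said of these compounds alone.

Measured so far in a functional assay on MCF7 cells (Homo sapiens) for antiproliferative activity, read by sulforhodamine B assay, with a stated time of 48 h; a lower number here means a stronger inhibitor, a higher number a weaker inhibitor:
compound 1, `CCCCCC(=O)Nc1ccc(S(=O)(=O)Oc2ccccc2C(C)C)cc1`, gives 5300 nM;
compound 2, `CCCCCC(=O)Nc1ccc(S(=O)(=O)Oc2ccccc2I)cc1`, gives 10000 nM;
compound 3, `CCNC(=O)Nc1ccc(S(=O)(=O)Oc2ccccc2C(C)C)cc1`, gives 10000 nM.

Compound 3 and compound 2 stand level in this assay, both at the high end of the three numbers. The core of compound 3 differs from that of compound 1 by ethylamino in place of pentyl on a carbonyl carbon, a step of a 1.9-fold higher number from compound 1 to compound 3 (0.28 log units; within the scatter). On the core of compound 1, the change iodo in place of isopropyl on an aromatic carbon gave a 1.9-fold higher number from compound 1 to compound 2 (0.28 log units; within the scatter).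

Compound 4, `CCNC(=O)Nc1ccc(S(=O)(=O)Oc2ccccc2I)cc1`, carries the same change on the core of compound 3, namely (iodo in place of isopropyl on an aromatic carbon). Within the data shown here, for compound 4 a step of about a 1.5-fold higher number from compound 3 to compound 4 (0.18 log units; within the scatter) is expected, resting on the single earlier instance, where compound 1 to compound 2 moved by a 1.9-fold higher number from compound 1 to compound 2 (0.28 log units; within the scatter). Compound 4 is therefore estimated at 15000 nM, with a likely range from 7000 nM to 40000 nM.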

Compound 4, half-maximal inhibitory concentration: 1100 nM
Compound 4: the middle estimate sits 14-fold (1.13 log units) above what was measured; the whole stated range lies above it.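

In this assay, compound 4 stands apart from the other three, with a 9.1-fold lower number from compound 3 to compound 4 (0.96 log units; beyond the scatter) and a 9.1-fold lower number from compound 2 to compound 4 (0.96 log units; beyond the scatter). Iodo in place of isopropyl on an aromatic carbon therefore does not carry over unchanged from one core to the other: the same change on two cores in this assay, a 1.9-fold higher number (0.28 log units; within the scatter) from compound 1 to compound 2 and a 9.1-fold lower number (0.96 log units; beyond the scatter) from compound 3 to compound 4, 17-fold (1.23 log units) apart, beyond the scatter of two such steps. The same holds for ethylamino in place of pentyl on a carbonyl carbon, so the two changes do not act independently here, though a single set of four compounds cannot show why or how general this is: the same change on two cores in this assay, a 1.9-fold higher number (0.28 log units; within the scatter) from compound 1 to compound 3 and a 9.1-fold lower number (0.96 log units; beyond the scatter) from compound 2 to compound 4, 17-fold (1.23 log units) apart, beyond the scatter of two such steps.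

As far as these compounds go, it remains open whether chloro or bromo on the same aromatic carbon would follow iodo. The same question stands for a propylamino or butylamino group on the carbonyl carbon in place of ethylamino.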